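The source may hold more compounds than are shown below. What is called first, only, known or untested is meant among the compounds shown, and "the series" means these compounds.

Measured so far:
compound 1 `COc1cccc(N(C)C(=O)c2ccc(Oc3ccc(Cl)cc3)cc2)c1`, 51%
compound 2 `O=S(=O)(c1cccc(O)c1)N1CCN(c2ccc(F)c(O)c2)CC1`, 48%
compound 3 `COc1cccc(S(=O)(=O)N2CCN(c3ccc(F)c(OC)c3)CC2)c1`, 15%

All three values come from an assay on microsomes from placenta for inhibition of 17-beta-hydroxysteroid dehydrogenase type 2 (Homo sapiens), read by HPLC, with a stated time of 20 min, tested at 1 uM; a higher number here means more inhibition at the concentration tested (going by the name of the read-out), a lower number less inhibition. Compound 2 stands second of the three numbers: against compound 1 its value lies within the scatter, so no order between them can be read, while compound 3 gives a reading far lower, beyond the scatter. Compound 4 `Cc1cccc(N2CCN(S(=O)(=O)c3cccc(O)c3)CC2)c1` is not yet measured. It differs from compound 2 in one place: 3-methylphenyl in place of 4-fluoro-3-hydroxyphenyl on an amine nitrogen in a ring. Among the compounds with values here, no step between measured compounds is known, so the size of the step in this assay can only be expected; a fall beyond the scatter is expected, a number 18 percentage points lower from compound 2 to compound 4 (beyond the scatter). The estimate for compound 4 in this assay is 30%, with a range from 10% to 52%.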

Compound 4, a percentage reported as inhibition, at one concentration (the size of the read-out at that concentration, not a potency): 27%
The estimate for compound 4 lay 3 percentage points above the measured number; the range from low to high includes it.
By their numbers in this assay, from the lowest: compound 3; then compound 4; then compounds 2 and 1 (each within the scatter of the next).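

In this assay the aryl group on the amine nitrogen in a ring affects the reading: 3-methylphenyl in place of 4-fluoro-3-hydroxyphenyl gives a number 21 percentage points lower from compound 2 to compound 4 (beyond the scatter) with the rest of the compound unchanged. Compound 4 still reads 27% in this assay, so inhibition at the concentration tested is reduced but not lost. Nothing available here accounts for the step.

On these data alone, the change alters fluorine, hydroxyl and methyl together, so the share of each remains open. Also open, as far as these compounds go, is how 3-aminophenyl or 3-carboxyphenyl in this place would read.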